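The source may hold more compounds than are shown below. What is called first, only, known or untested is meant among the compounds shown, and "the series" means these compounds.

Measured so far in a functional assay on HEp-2 cells (Homo sapiens) for inhibition, read by MTT assay, with a stated time of 72 h (on this read-out lower numbers stand for stronger inhibition and higher numbers for weaker inhibition), as follows
- compound 1 `CCCO[C@@H]1C=CC(=O)[C@@H](CO)O1` gives 13400 nM 
- compound 2 `O=C1C=C[C@@H](OC2CCCC2)O[C@@H]1CO` gives 8000 nM 
- compound 3 `O=C1C=C[C@@H](OC2CCCCC2)O[C@@H]1CO` gives 7500 nM 

Compound 2 at 8000 nM sits among the other two numbers and cannot be separated from either, with its gaps to compound 1 and compound 3 both within the scatter.

The next compound is compound 4 `CCO[C@@H]1C=CC(=O)[C@@H](CO)O1` with ethyl in place of cyclopentyl on an oxygen on a saturated carbon, the difference from compound 2 being ethyl in place of cyclopentyl on an oxygen on a saturated carbon in full.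

Among the compounds with values here, the one measured step bearing on this change is a 1.7-fold lower number from compound 1 to compound 2 (0.22 log units; within the scatter) and it also exchanges an open chain and cyclopentyl on an oxygen on a saturated carbon. Read in reverse, it points to little movement in this assay and, if any, a slight rise. Within the data shown here, no measured compound carries ethyl, and no step compares ethyl with propyl. A small rise not beyond the scatter is therefore expected, with compound 1 at 13400 nM as the closest measured open chain. The step expected on this estimate is a 1.5-fold higher number from compound 2 to compound 4 (0.18 log units; within the scatter) and no more. For compound 4 the estimated value is 12000 nM with an expected range from 6000 nM to 25000 nM as the working span.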

Compound 4, half-maximal inhibitory concentration: 5800 nM
Beside the measured number, compound 4's estimate is 2.1-fold (0.32 log units) above it; measured number outside the range, below it.
By their numbers in this assay, from the lowest: compounds 4, 3, 2 and 1 (each within the scatter of the next, the first and the last beyond it).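

In this assay, within the data shown here, the change from propyl to ethyl on the oxygen on a saturated carbon gives a 2.3-fold lower number from compound 1 to compound 4 (0.36 log units; beyond the scatter), the first step at this position to lie beyond the scatter, so a difference of a single methyl in the open chain can be read here, though only modestly. The exchange of cyclopentyl, with 5 heavy atoms and a ring, for ethyl, with 2 heavy atoms and no ring, gives a 1.4-fold lower number from compound 2 to compound 4 (0.14 log units; within the scatter), so in this pair the ring and the larger group bring no separable gain in the number. No supporting data accompany these compounds to explain the difference between the propyl and ethyl compounds.

From the compounds shown here alone, two open chains are too few to define a trend with chain length, and the outcome with methyl or a longer chain such as butyl on this oxygen remains open. Also open, going by these compounds, is how the number would respond to a polar group on the chain, such as an amine or a carboxylic acid, or to any change elsewhere in the shared core.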